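Methoxymethyl on an Aromatic Oxygen in Two Related Series

The source may report more compounds than this note shows. Statements on the series, on what has been measured and on what is new or still open speak of the compounds shown alone.

The study concerns a small set of compounds that share a core and differ in two places. Compound 1 `CC/C=C\C/C=C\C/C=C\CCCCCCCc1cc(=O)c2c(O)c(C)c(O)cc2o1` carries a hydrogen on an oxygen on an aromatic ring, while compound 2 `CC/C=C\C/C=C\C/C=C\CCCCCCCc1cc(=O)c2c(O)c(C)c(OCOC)cc2o1` carries a methoxymethyl there; the change is methoxymethyl in place of hydrogen on an oxygen on an aromatic ring. In a functional assay on MCF7 cells (Homo sapiens) for antiproliferative activity, read by MTT assay (on this read-out lower numbers stand for stronger inhibition and higher numbers for weaker inhibition), compound 1 gives 17500 nM, and compound 2 gives 17500 nM. The step of no change at the digits printed from compound 1 to compound 2 (within the scatter) shows that the change left the read-out where it was.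

Compound 3 `CCCCC/C=C\C/C=C\CCCCCCCc1cc(=O)c2c(O)cc(O)cc2o1` belongs to a second series; the difference between its core and the core of compound 1 is not broken down here. In this assay compound 3 gives 17500 nM, which stands level with compounds 1 and 2.

Compound 4 `CCCCC/C=C\C/C=C\CCCCCCCc1cc(=O)c2c(O)cc(OCOC)cc2o1` has not yet been measured. It differs from compound 3 by methoxymethyl in place of hydrogen on an oxygen on an aromatic ring. This is the same change as that from compound 1 to compound 2, on the same kind of place, and it occurs twice among the compounds shown.

The expected step of no change at the digits printed from compound 3 to compound 4 (within the scatter) rests on compound 1 and compound 2, because no change at the digits printed from compound 1 to compound 2 (within the scatter) showed no movement when the same change was made. On that basis compound 4 is expected to give about 17500 nM in this assay. The estimate for compound 4 is expected to lie between 9000 nM and 35000 nM.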

Compound 4, half-maximal inhibitory concentration: > 67200 nM
Compound 4 gave a limit, no number; the forecaster's own chance of this, stated with the estimate: 15%; middle value at least 3.8-fold (0.58 log units) from the limit.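

In this assay compound 4 gives > 67200 nM, which is a limit and not a number. On the second core, methoxymethyl in place of hydrogen gave an at least 3.8-fold higher number from compound 3 to compound 4 (0.58 log units; beyond the scatter), so the outcome of this change on the core of compound 1 did not carry over unchanged to the other core: the same change on two cores in this assay, no change at the digits printed (within the scatter) from compound 1 to compound 2 and an at least 3.8-fold higher number (0.58 log units; beyond the scatter) from compound 3 to compound 4, at least 3.8-fold (0.58 log units) apart, beyond the scatter of two such steps. The result shows that the same change can behave differently on these two cores, but it does not show the full size of the step, what in the two cores accounts for the gap, or how the change would behave on any other core.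

The compounds shown leave open whether methyl or acetyl on the same oxygen would separate the two cores in the same way. They also leave open whether a longer chain in place of methoxymethyl, such as methoxyethoxymethyl, would follow compound 2 or compound 4.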